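A methyl on the aromatic ring and solubility in quinone diamides

The compounds below may be only part of what the source reports. "The series", "measured", "known", "first", "only" and "open" are said of these compounds alone.

Three compounds sharing a cyclic core with two amino substituents have been measured in a physicochemical assay for solubility, read by HPLC, in phosphate buffer, with a stated time of 24 h, at pH 7.4, tested at 100 uM; a lower number here means a less soluble compound, a higher number a more soluble compound. Compound 1, `C[C@H](Nc1c(NCCCCCC(=O)NO)c(=O)c1=O)c1ccccc1`, gives 73000000 nM. Compound 2, `Cc1ccc([C@H](C)Nc2c(NCCCCCC(=O)NO)c(=O)c2=O)cc1`, gives 76000000 nM. Compound 3, `CC(CCCCC(=O)NO)Nc1c(Nc2ccccc2)c(=O)c1=O`, gives 93000000 nM. Compound 4, `Cc1ccc(Nc2c(NC(C)CCCCC(=O)NO)c(=O)c2=O)cc1`, has not been measured.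

Compound 2 differs from compound 1 by methyl in place of hydrogen on an aromatic carbon, and the step of a 1.0-fold higher number from compound 1 to compound 2 (0.02 log units; within the scatter). Compound 4 differs from compound 3 by methyl in place of hydrogen on an aromatic carbon, the same change at the same kind of place. How the core of compound 3 differs from the core of compound 1 is not broken down here; their values in this assay lie within the scatter of each other.

Since the earlier methyl step moved the number by an amount within the scatter, the step from compound 3 to compound 4 in this assay is expected to be a 1.0-fold lower number from compound 3 to compound 4 (0.01 log units; within the scatter), resting on a 1.0-fold higher number from compound 1 to compound 2 (0.02 log units; within the scatter). Compound 4 is therefore estimated at 90000000 nM, with a likely range from 50000000 nM to 150000000 nM.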

Compound 4, solubility: 83000000 nM
Estimate against measurement, compound 4: 1.1-fold (0.04 log units) above, and the stated range covers the measured number.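

The methyl has now been placed on two cores and read twice in this assay: on one core the result is (a 1.1-fold lower number from compound 3 to compound 4 (0.05 log units; within the scatter)), and on the other it is (a 1.0-fold higher number from compound 1 to compound 2 (0.02 log units; within the scatter)). Both steps lie within the scatter, so neither pair can be told apart, and the words "higher" and "lower" in the two steps should not be read as a real difference between the cores. This agreement does not show that the change would carry over from one core to the other in a case where a step rose beyond the scatter, and nothing measured here offers an explanation for either step.

From the compounds shown here alone, whether an amine, a carboxylic acid or a longer chain in place of the methyl on the aromatic carbon would give a step beyond the scatter remains open. Going by these compounds, whether the two cores would then answer alike, and how the methyl reads in any other kind of assay, also remain open.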